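The compounds below may be only part of what the source reports. "The series", "measured", "known", "first", "only" and "open" are said of these compounds alone.

Compound 1, `CCc1nnc(SCC(=O)c2ccccc2)n1N1C(=O)c2ccccc2C1=O`: > 200000 nM
Compound 2, `CCCc1nnc(SCC(=O)c2ccc(C)cc2)n1N1C(=O)c2ccccc2C1=O`: > 200000 nM

Both numbers come from a functional assay on HepG2 cells (Homo sapiens) for cytotoxicity, read by MTT assay, with a stated time of 48 h; on this read-out higher numbers stand for weaker inhibition and lower numbers for stronger inhibition. Compound 1 gives only a limit of the assay there, not a number. Compound 2 likewise gives only a limit of the assay, so no exact number is known for it either. On the numbers shown, compound 2 stands where every value shown stands: the limit of > 200000 nM in this assay, at which 2 of the 2 values shown sit. Compound 3, `CCCc1nnc(SCC(=O)c2ccccc2)n1N1C(=O)c2ccccc2C1=O`, has not yet been measured in this assay. It differs from compound 2 in one spot: hydrogen in place of methyl on an aromatic carbon, which in words is hydrogen in place of methyl on an aromatic carbon, or, cut one bond further out, 4-methylphenyl to phenyl. Among the compounds with values here, no step between two measured compounds is available, since compound 1 and compound 2 differ in more than one place; their two values show only that each sits at the limit. The expected step is a step that the limit leaves unreadable from compound 2 to compound 3, no change beyond the usual scatter in either direction. Compound 3 is therefore expected to give 250000 nM, within 100000 nM to 600000 nM, most likely reported again as a limit only.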

Compound 3, half-maximal inhibitory concentration: > 200000 nM
Compound 3 gave a limit, no number; the forecaster's own chance of this, stated with the estimate: 85%; the middle value is on the limit's open side.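

In this assay compound 3 gives > 200000 nM as a limit, not a number. Within the data shown here, compound 1 and compound 2 also give only limits, so no step to compound 3 can be read from either of them. The compounds shown leave open whether changing 4-methylphenyl to phenyl, or lengthening the chain by one methyl, alters the result in this assay at all.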